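The source may hold more compounds than are shown below. What is called first, only, known or untested is meant among the compounds shown, and "the series" means these compounds.

Three compounds of the shared core carry a cyclohexyl on the ring nitrogen: compound 1 `c1ccc(-c2cn3ccnc3c(-c3ccc4ncn(C5CCCCC5)c4c3)n2)cc1`, compound 2 `O=Cc1ccc(-c2cn3ccnc3c(-c3ccc4ncn(C5CCCCC5)c4c3)n2)cc1` and compound 3 `Clc1ccc(-c2cn3ccnc3c(-c3ccc4ncn(C5CCCCC5)c4c3)n2)cc1`. In a functional assay on HCT-15 cells (Homo sapiens) for inhibition, read by sulforhodamine B assay, with a stated time of 48 h, tested at 10 uM (a lower number here means less inhibition, a higher number more inhibition at the concentration tested (going by the name of the read-out)), compound 1 gives 51.6%, compound 2 gives 49.1% and compound 3 gives 15.5%. Compound 2 stands second of the three: it is separated from compound 1 by a number 2.5 percentage points lower from compound 1 to compound 2 (within the scatter) and from compound 3 by a number 33.6 percentage points lower from compound 2 to compound 3 (beyond the scatter), while the step of a number 36.1 percentage points lower from compound 1 to compound 3 (beyond the scatter) is of much the same size as the latter. Compound 4 `O=Cc1ccc(-c2cn3ccnc3c(-c3ccc4ncn(Cc5ccccc5)c4c3)n2)cc1` keeps the formyl of compound 2 and alters the other end of the molecule: benzyl in place of cyclohexyl on an aromatic nitrogen. None of the three measured steps concerns this position; each of them exchanges a group on the phenyl carbon, so the measured series says nothing direct about the exchange of cyclohexyl for benzyl on the ring nitrogen. Going by the values given here, with no step to rest on, the expectation for compound 4 in this assay is a number near that of compound 2, with a wide range around it. Compound 4 is therefore estimated at 45%, between 20% and 70%, which means an expected step of a number 4.1 percentage points lower from compound 2 to compound 4 (within the scatter).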

Compound 4, a percentage reported as inhibition, at one concentration (the size of the read-out at that concentration, not a potency): 49.1%
The estimate for compound 4 lay 4.1 percentage points below the measured number; low and high end bracket the measured number.
By their numbers in this assay, from the lowest: compound 3; then compounds 2, 4 and 1 (each within the scatter of the next).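

In this assay the exchange on the ring nitrogen gives no change at the digits printed from compound 2 to compound 4 (within the scatter) and so, with the formyl group held fixed, benzyl and cyclohexyl read alike within the scatter. Going by these compounds alone, this is the only reading at this position; the earlier steps all concern a group on the phenyl carbon, and the large a number 33.6 percentage points lower from compound 2 to compound 3 (beyond the scatter) has no counterpart in this exchange. Nothing measured on these compounds speaks to why the two rings read alike here.

Benzyl is shown only in compound 4, with formyl on the phenyl carbon, so how it reads with chloro there stays open. Also open, on these data alone, is how the ring nitrogen takes a group of another kind, such as a longer alkyl chain or a chain ending in an amine or a carboxylic acid.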